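This account rests on a few compounds, and the source may have more. Where it says the series, first, only, none or still open, it means among the compounds named here.

Measured compounds:
Compound 1 `COC(=O)C1=C(C)NC(C)=C(C(=O)OC)C1c1[nH]cnc1Cl` gives 1200 nM in an assay on isolated protein for inhibition of Voltage-dependent L-type calcium channel subunit alpha-1C (Cavia porcellus); on this read-out lower numbers stand for stronger inhibition and higher numbers for weaker inhibition.
Compound 3 `CCOC(=O)C1=C(C)NC(C)=C(C(=O)OC)C1c1[nH]cnc1Cl` gives 661 nM in this assay.
Compound 2 `CC1=C(C(=O)OC(C)(C)C)C(c2[nH]cnc2Cl)C(C(=O)OC(C)(C)C)=C(C)N1` gives 4070 nM in this assay.

Compound 3 has the lowest number of the three. Its nearest neighbour is compound 1, whose number is within the scatter of it; compound 2 lies beyond the scatter above it. Compound 4 `COC(=O)C1=C(C)NC(C)=C(C(=O)OC(C)(C)C)C1c1[nH]cnc1Cl` differs from compound 3 in one place: tert-butyl in place of ethyl on an oxygen next to a carbonyl group. Going by the values given here, only one measured step bears on this change, and only loosely. That step, a 1.8-fold lower number from compound 1 to compound 3 (0.26 log units; within the scatter), concerns a smaller chain at the same kind of place and lies within the scatter. Among the compounds with values here, compound 2, which carries tert-butyl at both such places, gives a higher number than compound 1, which carries methyl at both, but no single-change step joins them. The account therefore expects, for compound 4, at most a modest rise in the number in this assay, most likely within or near the scatter, with the change a 2.3-fold higher number from compound 3 to compound 4 (0.36 log units; beyond the scatter) the estimated step. Compound 4 is thus estimated at 1500 nM, with a range from 600 nM to 4000 nM.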

Compound 4, half-maximal inhibitory concentration: 1860 nM
Compound 4: middle estimate off by 1.2-fold (0.09 log units), on the low side, within the range that was stated.
By their numbers in this assay, from the lowest: compounds 3, 1 and 4 (each within the scatter of the next, the first and the last beyond it); then compound 2.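

In this assay, going by these compounds alone, the step from ethyl to tert-butyl on an oxygen next to a carbonyl group is the first single-place change at this kind of position to pass beyond the scatter: a 2.8-fold higher number from compound 3 to compound 4 (0.45 log units; beyond the scatter). Set against methyl at the same place, however, tert-butyl stays within the scatter, a 1.6-fold higher number from compound 1 to compound 4 (0.19 log units; within the scatter), and the step from methyl to ethyl is also within it, so among methyl, ethyl and tert-butyl only the ethyl and tert-butyl pair is clearly separated, and the three do not form a steady trend with chain size. With tert-butyl kept at one such place, replacing the second tert-butyl by methyl gives a 2.2-fold lower number from compound 2 to compound 4 (0.34 log units; beyond the scatter), which shows that the second tert-butyl adds to the number by a modest step beyond the scatter, whereas a single tert-butyl does not clearly separate from methyl.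

Nothing shown gives a measured reason for any of these steps. On these data alone, it remains open how a longer chain such as n-butyl, or a chain ending in an amine or a carboxylic acid, would read at this place, and whether the step from ethyl to tert-butyl would keep its size with ethyl rather than methyl at the other such place.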